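A few compounds are considered here, and "the series" means these few. Any claim that something is new, unique, unknown or untested is made for them only; others in the source may bear on it.

Compound 1 `CC(=O)OC[C@H]1O[C@@H](n2c(SCc3cc4ccccc4oc3=O)nc3cncnc32)[C@H](OC(C)=O)[C@@H]1OC(C)=O` — 39000 nM
Compound 2 `CC(=O)OC[C@H]1O[C@@H](n2c(SCc3cc4cc(Br)ccc4oc3=O)nc3cncnc32)[C@H](OC(C)=O)[C@@H]1OC(C)=O` — 6700 nM
Compound 3 `CC1(C)O[C@@H]2[C@H](O1)[C@H](n1c(SCc3cc4ccccc4oc3=O)nc3cncnc31)O[C@@H]2CO` — 8800 nM

These three compounds have been measured in a functional assay on Huh-5-2 cells (Homo sapiens) for cytotoxicity, read by microscopy; a higher number here means that more compound is tolerated, a lower number that less compound is tolerated. Compound 1 and compound 2 share one core and differ in a single place: bromo in place of hydrogen on an aromatic carbon. In this assay this change gave a 5.8-fold lower number from compound 1 to compound 2 (0.76 log units; beyond the scatter), so compound 2 is tolerated less well than compound 1. Compound 3 carries another core; the difference between the core of compound 1 and the core of compound 3 is not broken down here. The numbers for compound 2 and compound 3 lie within the usual scatter of each other, so nothing separates them in this assay.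

Compound 4 `CC1(C)O[C@@H]2[C@H](O1)[C@H](n1c(SCc3cc4cc(Br)ccc4oc3=O)nc3cncnc31)O[C@@H]2CO` has not yet been measured. It is built from compound 3 by bromo in place of hydrogen on an aromatic carbon. Going by the values given here, this is the same change as the one from compound 1 to compound 2, at the same kind of place, now made on the core of compound 3. Among the compounds with values here, the only guide to its effect is the single earlier step, and there is no second example to show whether the core of compound 3 responds in the same way. Because a 5.8-fold lower number from compound 1 to compound 2 (0.76 log units; beyond the scatter) lies beyond the scatter, a step in the same direction is expected, written as a 4.0-fold lower number from compound 3 to compound 4 (0.60 log units; beyond the scatter), though tempered somewhat for the untested core. Compound 4 is therefore estimated to give about 2200 nM in this assay, most likely between 800 nM and 6500 nM.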

Compound 4, half-maximal cytotoxic concentration: 7500 nM
Compound 4: middle estimate off by 3.4-fold (0.53 log units), on the low side; measured number above the stated range.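

In this assay, bromo in place of hydrogen on an aromatic carbon gave a 1.2-fold lower number from compound 3 to compound 4 (0.07 log units; within the scatter), so compound 3 and compound 4 cannot be told apart by this measurement. The same change, made at the same kind of place, therefore did not carry over at the same size, and the size of its step in this series depends on the core that carries it: the same change on two cores in this assay, a 5.8-fold lower number (0.76 log units; beyond the scatter) from compound 1 to compound 2 and a 1.2-fold lower number (0.07 log units; within the scatter) from compound 3 to compound 4, 5.0-fold (0.70 log units) apart, beyond the scatter of two such steps. Going by these compounds alone, what this does not show is which feature of the two cores sets the steps apart, and with only one pair on each core it gives no general rule for the series.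

The compounds shown carry only hydrogen or bromo at this place, so it remains open whether another group, such as chloro, methoxy or an amine, would behave as in the pair of compound 1 and compound 2 or as in the pair of compound 3 and compound 4. As far as these compounds go, it also remains open how the bromo change would read on a third core, and whether the contrast between these two cores would appear in any measurement other than this assay.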